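Ring methyl on compound 2

The compounds below may be only part of what the source reports. "The series", "measured", "known", "first", "only" and "open" are said of these compounds alone.

compound 1 `CC(=O)N(C)CC#CCn1cncc1C` gives 5.4 mg/kg
compound 2 `COC(=O)N(C)CC#CCn1ccnc1` gives 2 mg/kg

Among the compounds with values here, in a functional assay on the whole organism for agonist activity, with Mus musculus as the target (a lower number here means that less compound is needed, a higher number that more compound is needed for the effect), compound 2 gives 2 mg/kg and holds the lower of the two numbers so far. The gap to compound 1 lies beyond the scatter.

The next entry is compound 3 `COC(=O)N(C)CC#CCn1cncc1C` and it has not yet been measured. It arises from compound 2 through methyl in place of hydrogen on an aromatic carbon.

Within the data shown here, no measured pair shows this exchange alone, so any expectation here is loose. Compound 1 also carries this ring methyl, and with compound 1 at 5.4 mg/kg in this assay a drift towards a higher number is expected rather than a lower one. That single value is weak support. The expected change is a 1.5-fold higher number from compound 2 to compound 3 (0.18 log units; within the scatter) and this estimated step stays within the scatter, leaning to the higher side. For compound 3 the estimated value is 3 mg/kg with an expected range from 1 mg/kg to 9 mg/kg in this assay when it is measured.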

Compound 3, dose for half-maximal effect: 4.5 mg/kg
Estimate against measurement, compound 3: 1.5-fold (0.18 log units) below; the range from low to high includes it.
By their numbers in this assay, from the lowest: compound 2; then compounds 3 and 1 (each within the scatter of the next).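

In this assay the ring methyl can now be read on its own: a 2.3-fold higher number from compound 2 to compound 3 (0.35 log units; beyond the scatter). With the methoxy on the carbonyl carbon kept, the ring methyl, next to the ring nitrogen and next to the ring atom that bears a large group, therefore comes with a modest rise in the dose needed, and hydrogen remains the better of the two groups here. The carbonyl carbon also gets its first single-place reading, a 1.2-fold lower number from compound 1 to compound 3 (0.08 log units; within the scatter), so with the ring methyl in place, methoxy and methyl cannot be told apart at that carbon in this assay, and no measurement on hand accounts for either step.

The compounds shown leave open whether the ring methyl shifts the dose to the same extent when methyl rather than methoxy sits on the carbonyl carbon. They also leave open how a larger group at this ring carbon, such as ethyl or trifluoromethyl, or an amine on the carbonyl carbon in place of methoxy, would read in this assay.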